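Series notes: fluoro to hydroxy on the benzyl ring

This account rests on a few compounds, and the source may have more. Where it says the series, first, only, none or still open, it means among the compounds named here.

Going by the values given here, in a physicochemical assay for solubility, at pH 6.8 (on this read-out lower numbers stand for lower solubility and higher numbers for higher solubility), compound 3 `O=[N+]([O-])c1cn2c(n1)OC[C@@H](NCc1ccc(OC(F)(F)F)cc1F)C2` gives 72 ug/mL, the only plain number among the three values shown. Compound 1 `CC(C)N(Cc1ccc(OC(F)(F)F)cc1)[C@@H]1COc2nc([N+](=O)[O-])cn2C1` reaches only a limit, < 2 ug/mL. Compound 2 `CCCN(Cc1ccc(OC(F)(F)F)cc1)[C@@H]1COc2nc([N+](=O)[O-])cn2C1` likewise sits at a limit, < 2 ug/mL. The step that the two limits leave unreadable from compound 1 to compound 2, propyl in place of isopropyl on an amine nitrogen, has no readable size because of the limit of < 2 ug/mL in this assay, at which 2 of the 3 values shown sit. Compound 4 `O=[N+]([O-])c1cn2c(n1)OC[C@@H](NCc1ccc(OC(F)(F)F)cc1O)C2` differs from compound 3 by hydroxy in place of fluoro on an aromatic carbon. Among the compounds with values here, no measured step changes the group at this position; the one measured step concerns the amine nitrogen and carries no readable size, so it offers no guide to the direction or size of this change in this assay. Compound 4 is therefore expected to land near compound 3, with an estimated step of a 1.4-fold higher number from compound 3 to compound 4 (0.14 log units; within the scatter) that is not expected to pass beyond the scatter. The estimate for compound 4 in this assay is 100 ug/mL, with a range from 35 ug/mL to 280 ug/mL.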

Compound 4, solubility: 25 ug/mL
The estimate for compound 4 lay 4.0-fold (0.60 log units) above the measured number; measured number below the stated range.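

Hydroxy in place of fluoro gives a 2.9-fold lower number from compound 3 to compound 4 (0.46 log units; beyond the scatter) in this assay and provides the first readable step in the series; the only earlier step, on the amine nitrogen, cannot be read. This position on the benzyl ring is therefore not neutral on this read-out: exchanging one heavy atom for another, on an aromatic carbon ortho to a large group and meta to a trifluoromethoxy group, moves the number beyond the scatter. This single pair fixes the direction for these two groups only and gives no rule for others at this position.

As far as these compounds go, whether a methoxy, a chloro or an amine here would stay closer to compound 3 or to compound 4 remains open, as does whether the same change would hold with propyl on the amine nitrogen. Nothing among the measurements shown bears on what lies behind this step.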